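A few compounds are considered here, and "the series" means these few. Any claim that something is new, unique, unknown or untested is made for them only; others in the source may bear on it.

In a functional assay on MOLT-4 cells (Homo sapiens) for inhibition, read by sulforhodamine B assay, with a stated time of 48 h, tested at 10 uM (on this read-out lower numbers stand for less inhibition of growth and higher numbers for more inhibition of growth at the one concentration tested), compound 2 `c1ccc(-c2nc3sc(-c4ccccc4)cn3n2)cc1` gives 11%, the lowest of the three numbers at hand. Compound 1 `C/C(=N\O)c1ccc(NC(=O)Cn2nc(-c3ccc(Cl)cc3)nc2N)cc1` gives 33%, a number beyond the scatter above that of compound 2. Compound 3 `COc1cc(-c2nc3sc(-c4ccccc4)cn3n2)cc(OC)c1OC`, built on the shared core, gives 44%, the furthest above compound 2, beyond the scatter. Compound 4 `Clc1ccc(-c2cn3nc(-c4ccccc4)nc3s2)cc1` differs from compound 2 in one place: chloro in place of hydrogen on an aromatic carbon, the change reading, one bond further out, as phenyl to 4-chlorophenyl. For the measured compounds named here, no measured pair in this assay shows this change on its own, so its size is unknown. The step of a number 9 percentage points higher from compound 2 to compound 4 (within the scatter) is estimated as a modest rise in growth inhibition, possibly within the scatter. Compound 4 is expected to give about 20%, in a range from 5% to 40%.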

Compound 4, percent growth inhibition at one concentration: 8%
Estimate against measurement, compound 4: 12 percentage points above; measured number inside the range.
By their numbers in this assay, from the lowest: compounds 4 and 2 (each within the scatter of the next); then compound 1; then compound 3.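

In this assay, for the compounds shown here, chloro in place of hydrogen, para to a large group, gives a number 3 percentage points lower from compound 2 to compound 4 (within the scatter) and is the first measured instance of this change. At this position and at the one concentration tested, going from phenyl to 4-chlorophenyl does not separate the two compounds. Nothing at hand offers an explanation for this result.

The compounds shown leave open whether an amine or a carboxylic acid at the same position would give a number set apart from compound 2. They also leave open whether chloro would read the same on the core of compound 3.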